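Moving the Nitrogen Along the Ketone Chain

This account rests on a few compounds, and the source may have more. Where it says the series, first, only, none or still open, it means among the compounds named here.

Compound 1 `COc1cc(COc2cc(N)c(Cl)cc2C(=O)CCCCN2CCC(c3ccccc3)CC2)cc(OC)c1` gives 7.7 in a functional assay for antagonist activity at 5-hydroxytryptamine receptor 4 (Rattus norvegicus); a lower number here means a less potent compound, a higher number a more potent compound, by a factor of ten per unit of this negative logarithm. Compound 2 `COc1cc(COc2cc(N)c(Cl)cc2C(=O)CCCCN2CCC(O)CC2)cc(OC)c1`, with hydroxy in place of phenyl on a saturated ring carbon, gives 8.3 in this assay, and compound 3 `COc1cc(COc2cc(N)c(Cl)cc2C(=O)CCCCN2CCC(CCNS(C)(=O)=O)CC2)cc(OC)c1`, carrying 2-(methanesulfonamido)ethyl on that carbon, gives 8.1. Compound 2 stands highest of the three numbers, yet its gap to compound 3 lies within the scatter, and only its gap to compound 1 lies beyond it. The measured steps are all modest: a number 0.60 log units higher from compound 1 to compound 2 (beyond the scatter), a number 0.40 log units higher from compound 1 to compound 3 (beyond the scatter), while a number 0.20 log units lower from compound 2 to compound 3 (within the scatter).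

Compound 4 `CCCCCN1CCC(CCC(=O)c2cc(Cl)c(N)cc2OCc2cc(OC)cc(OC)c2)CC1` departs from compound 2 in a different way: 1-pentylpiperidin-4-yl in place of 2-(4-hydroxypiperidin-1-yl)ethyl on a saturated chain carbon, two bonds along the chain from a carbonyl carbon. The ring nitrogen no longer ends the chain, a pentyl now sits on it, and the hydroxy donor is gone. For the measured compounds named here, none of the measured steps bears directly on this change; each of them altered only the group on a saturated ring carbon and shifted the number modestly. Since the variation here reaches the chain and the ring nitrogen itself, a drop beyond the scatter is expected, a number 1.00 log units lower from compound 2 to compound 4 (beyond the scatter). Compound 4 is therefore estimated at 7.3, with a range from 6.3 to 8.3.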

Compound 4, negative logarithm of the antagonist equilibrium constant: 9.1
The estimate for compound 4 lay 1.80 log units below the measured number, and the stated range ends below it.
By their numbers in this assay, from the lowest: compound 1; then compounds 3 and 2 (each within the scatter of the next); then compound 4.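

Replacing 2-(4-hydroxypiperidin-1-yl)ethyl with 1-pentylpiperidin-4-yl on a saturated chain carbon, two bonds along the chain from a carbonyl carbon, gives a number a number 0.80 log units higher from compound 2 to compound 4 (beyond the scatter) in this assay, so this place tolerates a change that reaches the chain and the ring nitrogen, and the number can rise there. The earlier compounds shown here varied only the group on a saturated ring carbon, and among them compound 2, with its hydroxy, stood highest; compound 4 reaches 9.1 with an entering group that has 0 hydrogen-bond donors, so the hydroxy is not required for a number at this level. Nothing available here explains the rise.

This single step changes the place of the ring nitrogen along the chain, adds the pentyl on that nitrogen and removes the hydroxy all at once, and the compounds shown do not separate these three changes. On these data alone, it remains open how the number would respond to a shorter or longer group on that nitrogen, such as butyl or hexyl, to a benzyl there, or to a hydroxy restored on the piperidine ring of compound 4.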